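The compounds below may be only part of what the source reports. "The series", "measured", "known", "first", "only" and "open" are said of these compounds alone.

For the measured compounds named here, compound 2 `CC(C)(C)c1ccc(NC(=O)c2ccc(-c3ncccc3NS(C)(=O)=O)cc2)cc1` gives 35 nM in a functional assay for antagonist activity at transient receptor potential cation channel subfamily V member 1 (Rattus norvegicus) (on this read-out lower numbers stand for stronger inhibition and higher numbers for weaker inhibition), the higher of the two numbers so far; compound 1 `Cc1cccnc1-c1ccc(C(=O)Nc2ccc(C(C)(C)C)cc2)cc1` gives 9 nM. Going by the values given here, the only measured step, a 3.9-fold higher number from compound 1 to compound 2 (0.59 log units; beyond the scatter), shows that methanesulfonamido in place of methyl raised the number. Compound 3 `CC(C)(C)c1ccc(NC(=O)c2ccc(-c3ncccc3C(=N)N)cc2)cc1` differs from compound 2 by a group of 3 heavy atoms (1 carbon, 2 nitrogen; no ring) in place of a group of 5 heavy atoms (1 carbon, 1 nitrogen, 2 oxygen, 1 sulfur; no ring), on an aromatic carbon. Among the compounds with values here, no measured step involves the entering group, so the step from compound 1 to compound 2 bears on it only indirectly. Compound 3 is therefore expected near compound 2, with a 1.1-fold higher number from compound 2 to compound 3 (0.06 log units; within the scatter) not beyond the scatter. The estimate for compound 3 is 40 nM, within 8 nM to 200 nM.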

Compound 3, half-maximal inhibitory concentration: > 4000 nM
Compound 3 was reported as a limit (the forecaster's own chance of this, stated with the estimate: 5%); middle value at least 100-fold (2.00 log units) from the limit.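

The earlier step moved this position only modestly, but the entering group gives an at least 110-fold higher number from compound 2 to compound 3 (2.05 log units; beyond the scatter) and an at least 440-fold higher number from compound 1 to compound 3 (2.64 log units; beyond the scatter) on the same aromatic carbon. Methyl and methanesulfonamido both leave measurable inhibition in this assay while this group of 3 heavy atoms does not, so the position is far less forgiving than the first pair suggested.

Whether a primary amine or a carboxylic acid on this carbon would track compound 2 or compound 3 remains open, and no cause for the loss can be drawn from these compounds. The true size of both new steps also stays open, since compound 3 is reported only as a limit: the limit of > 4000 nM in this assay, at which 1 of the 3 values shown sits.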